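From phenyl to 3,4-dimethoxyphenyl in compound 4

This account rests on a few compounds, and the source may have more. Where it says the series, first, only, none or still open, it means among the compounds named here.

In a functional assay on A549 cells (Homo sapiens) for inhibition, read by sulforhodamine B assay (on this read-out higher numbers stand for weaker inhibition of growth and lower numbers for stronger inhibition of growth), compound 1 `c1ccc(-c2ccc(-c3ccc(-c4nc5ccccc5[nH]4)cc3)cc2)cc1` gives 41200 nM. Compound 2 `CN(C)c1ccc(-c2ccc(-c3ccc(-c4nc5ccccc5[nH]4)cc3)cc2)cc1` gives 30100 nM, and compound 3 `Clc1cccc(-c2ccc(-c3ccc(-c4nc5ccccc5[nH]4)cc3)cc2)c1` gives 31100 nM, so compound 1 stands within the scatter of both. Compound 4 `COc1ccc(-c2ccc(-c3ccc(-c4nc5ccccc5[nH]4)cc3)cc2)cc1OC` differs from compound 1 by a single change: 3,4-dimethoxyphenyl in place of phenyl on an aromatic carbon. Among the measured compounds shown here, two measured steps bear on this change. Dimethylamino gave a 1.4-fold lower number from compound 1 to compound 2 (0.14 log units; within the scatter), and chloro gave a 1.3-fold lower number from compound 1 to compound 3 (0.12 log units; within the scatter). For the measured compounds named here, neither step exceeds the scatter, although no compound with a methoxy group has yet been measured. No step beyond the scatter is therefore expected in this assay. The expected step is a 1.4-fold lower number from compound 1 to compound 4 (0.14 log units; within the scatter). Compound 4 is estimated at 30000 nM, with an expected range from 14000 nM to 62000 nM.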

Compound 4, concentration for 50% growth inhibition: 7600 nM
Estimate against measurement, compound 4: 3.9-fold (0.60 log units) above, and the stated range ends above it.
By their numbers in this assay, from the lowest: compound 4; then compounds 2, 3 and 1 (each within the scatter of the next).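

The position is not indifferent to substitution in this assay: 3,4-dimethoxyphenyl gives a 5.4-fold lower number from compound 1 to compound 4 (0.73 log units; beyond the scatter) and so moves beyond the scatter, which neither earlier change did. The same change also separates compound 4 from both substituted compounds, with a 4.1-fold lower number from compound 3 to compound 4 (0.61 log units; beyond the scatter) and a 4.0-fold lower number from compound 2 to compound 4 (0.60 log units; beyond the scatter) as its steps. No evidence is available to explain why this change differs from dimethylamino and chloro.

The compounds shown leave open whether a single methoxy group would give a step of this size. They also leave open how an ethoxy group or a carboxylic acid would behave at this place.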